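Adding 3-hydroxybutyl to the amine of compound 3

The source may hold more compounds than are shown below. What is called first, only, known or untested is meant among the compounds shown, and "the series" means these compounds.

Measured so far in a functional assay (Pituitary gland cell) with Rattus norvegicus as the target; a higher number here means that more compound is needed for the effect, a lower number that less compound is needed:
- compound 1 `CC(C)[C@@H](O)CNC(C)(C)CC(=O)N[C@@H]1CCc2ccccc2N(Cc2ccc(-c3ccccc3-c3nn[nH]n3)cc2)C1=O`: 200 nM
- compound 2 `CC(C)(CC(=O)N[C@@H]1CCc2ccccc2N(Cc2ccc(-c3ccccc3-c3nn[nH]n3)cc2)C1=O)NC[C@H](O)[C@@H](O)CO`: 40 nM
- compound 3 `CC(C)(N)C(=O)N[C@@H]1CCc2ccccc2N(Cc2ccc(-c3ccccc3-c3nn[nH]n3)cc2)C1=O`: 30 nM

In this assay, compound 3 gives 30 nM, which lies within the scatter of compound 2 and well clear of compound 1. The next compound, compound 4 `C[C@H](O)CCNC(C)(C)C(=O)N[C@@H]1CCc2ccccc2N(Cc2ccc(-c3ccccc3-c3nn[nH]n3)cc2)C1=O`, keeps everything in compound 3 except for one change: 3-hydroxybutyl in place of hydrogen on an amine nitrogen.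

For the measured compounds named here, no measured step makes this change alone. The closest evidence comes from compound 1 and compound 2, which both carry a substituent on the amine nitrogen, but their chain to the carbonyl also differs from that of compound 3. The two steps that bear on this change therefore mix both differences, and they disagree. One is a 6.7-fold lower number from compound 1 to compound 3 (0.82 log units; beyond the scatter), while the other is a 1.3-fold lower number from compound 2 to compound 3 (0.12 log units; within the scatter). The identity of the substituent also matters, as shown by a 5.0-fold lower number from compound 1 to compound 2 (0.70 log units; beyond the scatter).

Read together, these steps suggest that a substituted amine may bring no change or a modest rise in the number, depending on the substituent. The expected step is a 2.0-fold higher number from compound 3 to compound 4 (0.30 log units; within the scatter), a rough estimate in the upward direction. For compound 4, the estimated value in this assay is 60 nM, with an expected range from 20 nM to 200 nM.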

Compound 4, concentration for half-maximal effect: 50 nM
The estimate for compound 4 lay 1.2-fold (0.08 log units) above the measured number; low and high end bracket the measured number.
By their numbers in this assay, from the lowest: compounds 3, 2 and 4 (each within the scatter of the next); then compound 1.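

In this assay, for the compounds shown here, the change gives a 1.7-fold higher number from compound 3 to compound 4 (0.22 log units; within the scatter) and so offers the first direct reading at this amine nitrogen: a 3-hydroxybutyl group, with its 5 heavy atoms and one defined stereocentre, can replace hydrogen without a step beyond the scatter. Replacing the whole group on the carbonyl carbon gives a 1.3-fold higher number from compound 2 to compound 4 (0.10 log units; within the scatter) but also a 4.0-fold lower number from compound 1 to compound 4 (0.60 log units; beyond the scatter), so compound 1 alone stands apart from the other three, although these two steps alter the chain to the carbonyl as well as the substituent on the nitrogen. No available measurement explains why the substituent is tolerated or why compound 1 differs.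

The compounds shown leave open what a plain butyl group on this nitrogen would give, and whether the opposite configuration at the stereocentre of 3-hydroxybutyl would give a similar number. They also do not show how a longer chain, or a carboxylic acid or amine at the end of this substituent, would read in this assay at this position.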